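Aryl tail chain length and tolerated concentration in HeLa cells

The source may hold more compounds than are shown below. What is called first, only, known or untested is meant among the compounds shown, and "the series" means these compounds.

Measured so far:
Compound 1 `CCCCc1ccc(-c2cc3cn([C@H]4C[C@H](O)[C@@H](CO)O4)c(=O)nc3s2)cc1` in a functional assay on HeLa cells (Homo sapiens) for cytotoxicity; a lower number here means that less compound is tolerated, a higher number that more compound is tolerated: compound 1 gives > 200000 nM, a limit of the assay.
Compound 2 `CCCCCCCCc1cc2cn([C@H]3C[C@H](O)[C@@H](CO)O3)c(=O)nc2s1`: compound 2 gives 53000 nM.
Compound 3 `CCCCCCCc1ccc(-c2cc3cn([C@H]4C[C@H](O)[C@@H](CO)O4)c(=O)nc3s2)cc1`: compound 3 gives > 200000 nM, a limit of the assay.

Compound 3 therefore stands at the limit of > 200000 nM in this assay, at which 2 of the 3 values shown sit, and no number is known for it. Compound 2 is the only one of the three with a number. For the measured compounds named here, the one step that links two measured compounds, a step that the two limits leave unreadable from compound 1 to compound 3, joins two limits and cannot be read in size or direction; it is the only measured step that shares the shortened tail with the change now followed.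

Compound 4 `CCCc1ccc(-c2cc3cn([C@H]4C[C@H](O)[C@@H](CO)O4)c(=O)nc3s2)cc1` differs from compound 3 as hydrogen in place of butyl on a saturated chain carbon, three bonds along the chain from an aromatic carbon. No readable step bears on this change. Compound 1 and compound 3, at either end of the tail-length range shown, both sit at the limit, so compound 4 is expected to sit there as well. For compound 4 the expected value is 200000 nM, in a range from 100000 nM to 400000 nM; the expected step from compound 3 is a number no higher from compound 3 to compound 4 (the limit leaves the size open), that is, no change beyond the scatter, with most likely only a limit reported.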

Compound 4, half-maximal cytotoxic concentration: > 200000 nM
Compound 4: only a limit was reported (the forecaster's own chance of this, stated with the estimate: 80%); the middle value lies on the limit itself.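

In this assay the series now has a readable step for a short aryl tail: with 4-propylphenyl in place of octyl on an aromatic carbon, the change is an at least 3.7-fold higher number from compound 2 to compound 4 (0.57 log units; beyond the scatter). With propyl, the aryl tails now run from propyl through butyl to heptyl, and compound 1, compound 3 and compound 4 all report the same limit of the assay: the limit of > 200000 nM in this assay, at which 3 of the 4 values shown sit. The steps among these three compounds join limits and cannot be read, so chain length on the aryl group shows neither size nor direction here.

How far above the limit each of these compounds lies remains open. Also open, on these data alone, is whether a decyl tail, or an amine on the tail, in place of propyl would bring a number within the range of this assay.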